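The source may report more compounds than this note shows. Statements on the series, on what has been measured and on what is new or still open speak of the compounds shown alone.

Within the data shown here, in a physicochemical assay for solubility, read by HPLC (on this read-out higher numbers stand for higher solubility and lower numbers for lower solubility), compound 3 `CCCCC(=O)N1CCN(c2nc(=O)c3cc(C(F)(F)F)cc([N+](=O)[O-])c3s2)CC1` gives 42.5 ug/mL, the highest of the three numbers so far. Compound 1 `CSCC(=O)N1CCN(c2nc(=O)c3cc(C(F)(F)F)cc([N+](=O)[O-])c3s2)CC1` gives 15.2 ug/mL, and compound 2 `CC(C)(C)C(=O)N1CCN(c2nc(=O)c3cc(C(F)(F)F)cc([N+](=O)[O-])c3s2)CC1` gives 5.87 ug/mL. Among the measured compounds shown here, the steps that bear on the carbonyl substituent are a 2.8-fold higher number from compound 1 to compound 3 (0.45 log units; beyond the scatter) and a 7.2-fold higher number from compound 2 to compound 3 (0.86 log units; beyond the scatter); the remaining step is a 2.6-fold lower number from compound 1 to compound 2 (0.41 log units; beyond the scatter). Compound 4 `O=C(c1cccc(F)c1)N1CCN(c2nc(=O)c3cc(C(F)(F)F)cc([N+](=O)[O-])c3s2)CC1` differs from compound 3 by 3-fluorophenyl in place of butyl on a carbonyl carbon. For the measured compounds named here, none of the measured steps brings an aromatic ring onto this carbonyl carbon, so the only guide is that changes at this position have moved this assay by modest amounts in either direction. A modestly lower number is expected for compound 4, the step being a 4.3-fold lower number from compound 3 to compound 4 (0.63 log units; beyond the scatter). For compound 4 the estimate is 10 ug/mL, with a range from 3 ug/mL to 30 ug/mL.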

Compound 4, solubility: 0.2 ug/mL
Estimate against measurement, compound 4: 50-fold (1.70 log units) above; the whole stated range lies above it.
By their numbers in this assay, from the lowest: compound 4; then compound 2; then compound 1; then compound 3.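

In this assay, 3-fluorophenyl in place of an open-chain group on this carbonyl carbon gives a 210-fold lower number from compound 3 to compound 4 (2.33 log units; beyond the scatter) and a 76-fold lower number from compound 1 to compound 4 (1.88 log units; beyond the scatter) and also a 29-fold lower number from compound 2 to compound 4 (1.47 log units; beyond the scatter) as three large steps. The steps among butyl, tert-butyl and (methylsulfanyl)methyl were all modest, so this position can move the read-out far more than those compounds showed. No supporting measurement explains the size of these steps.

Among these compounds, with 3-fluorophenyl the only aromatic group here, it remains open whether the step belongs to the ring or to the fluorine. Plain phenyl and cyclohexyl at this carbonyl carbon would separate the two.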